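The source may report more compounds than this note shows. Statements on the series, on what has been measured and on what is new or still open speak of the compounds shown alone.

Compound 1 `COc1ncc(-c2ccc3c(c2)N(c2ccc(C)cc2)C(=O)CO3)cc1NS(=O)(=O)c1ccc(F)cc1`: 28300 nM
Compound 2 `COc1ccc(N2C(=O)COc3ccc(-c4cnc(OC)c(NS(=O)(=O)c5ccc(F)cc5)c4)cc32)cc1`: 13100 nM
Compound 3 `O=C1COc2ccc(-c3cnc4ccccc4c3)cc2N1c1ccccc1`: a limit, > 40000 nM

In a functional assay on HepG2 cells (Homo sapiens) for antiproliferative activity, read by MTT assay, with a stated time of 72 h (on this read-out higher numbers stand for weaker inhibition and lower numbers for stronger inhibition), compound 2 gives 13100 nM, the lowest of the two plain numbers shown. Its nearest neighbour is compound 1, which gives 28300 nM. Compound 3 reaches only the limit of the assay, > 40000 nM. That edge of the assay is marked by the limit of > 40000 nM in this assay, at which 1 of the 3 values shown sits.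

Compound 4 `COc1ncc(-c2ccc3c(c2)N(c2ccc(F)cc2)C(=O)CO3)cc1NS(=O)(=O)c1ccc(F)cc1` has not yet been measured in this assay. It differs from compound 2 in one place: fluoro in place of methoxy on an aromatic carbon. Going by the values given here, only one measured step touches that same aromatic carbon, namely a 2.2-fold lower number from compound 1 to compound 2 (0.33 log units; beyond the scatter), where methoxy arriving in place of methyl brought a modest gain. Compound 4 now removes that methoxy and puts fluoro there instead, so the expectation is that part of this modest gain is given back, a small step toward a higher number, of a size near the edge of the scatter.

Compound 4 is therefore estimated at 20000 nM, in a range from 9000 nM to 45000 nM, which means an expected step of a 1.5-fold higher number from compound 2 to compound 4 (0.18 log units; within the scatter).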

Compound 4, half-maximal inhibitory concentration: 36400 nM
Compound 4: middle estimate off by 1.8-fold (0.26 log units), on the low side; measured number inside the range.
By their numbers in this assay, from the lowest: compound 2; then compounds 1 and 4 (each within the scatter of the next). At a limit, above all of these: compound 3.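

Going from 4-methoxyphenyl to 4-fluorophenyl, para to a large group, gives a 2.8-fold higher number from compound 2 to compound 4 (0.44 log units; beyond the scatter), so the lower number of compound 2 does not carry over to fluoro. Fluoro and methyl cannot be told apart at this place, with a 1.3-fold higher number from compound 1 to compound 4 (0.11 log units; within the scatter), which means that of the three groups shown, only methoxy stands apart from the other two. Compounds 1 and 4 also lie close to the upper edge of what can be read, which leaves little room to rank any weaker group at this place: the limit of > 40000 nM in this assay, at which 1 of the 4 values shown sits.

The compounds shown leave open whether the oxygen of methoxy is what matters, and a hydroxyl, an ethoxy or a dimethylamino group at this place would test that. They also leave open whether a larger step down in number is possible here at all.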